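This account rests on a few compounds, and the source may have more. Where it says the series, first, only, none or still open, it means among the compounds named here.

Measured so far:
- compound 1 `CNc1ncnc2c1c(-c1cccs1)cn2[C@@H]1O[C@H](CO)[C@@H](O)[C@H]1O`: > 20000 nM
- compound 2 `Nc1nc(N)c2c(-c3cccs3)cn([C@@H]3O[C@H](CO)[C@@H](O)[C@H]3O)c2n1`: > 20000 nM

Both values come from a functional assay on CCRF-CEM cells (Homo sapiens), read by MTT assay, with a stated time of 72 h (on this read-out higher numbers stand for weaker inhibition and lower numbers for stronger inhibition), and both sit at the same limit, (the limit of > 20000 nM in this assay, at which 2 of the 2 values shown sit). In this assay compound 2 gives > 20000 nM, which is a limit of the assay and not a number. For the measured compounds named here, its true value is therefore unknown, and no measured step yet shows how a change to this structure plays out.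

Compound 3 `Nc1nc(N)c2c(-c3cc4ccccc4o3)cn([C@@H]3O[C@H](CO)[C@@H](O)[C@H]3O)c2n1` keeps the core and the sugar portion of compound 2 but has 1-benzofuran-2-yl in place of thiophen-2-yl on an aromatic carbon, (1-benzofuran-2-yl in place of thiophen-2-yl on an aromatic carbon). A small gain in strength is expected for an at least 1.3-fold lower number from compound 2 to compound 3 (0.12 log units; that floor lies within the scatter), and it may not go beyond the usual scatter. The assay may well report only a limit again. For compound 3 the estimated value is 15000 nM, with an expected range of 4000 nM to 30000 nM.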

Compound 3, half-maximal inhibitory concentration: > 20000 nM
Compound 3 was reported as a limit (the forecaster's own chance of this, stated with the estimate: 65%); middle value at least 1.3-fold (0.12 log units) from the limit.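

Compound 2 and compound 3 both sit at a limit of this assay, so no step between them can be read: the limit of > 20000 nM in this assay, at which 3 of the 3 values shown sit.

On these data alone, whether 1-benzofuran-2-yl in place of thiophen-2-yl changes the strength at all stays open, as do the true values of compound 1, compound 2 and compound 3.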